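Putting a Nitrogen Back Where a Methyl Stands

This account rests on a few compounds, and the source may have more. Where it says the series, first, only, none or still open, it means among the compounds named here.

Of the compounds shown here, three sharing one core have been tested in an assay for binding affinity to Neuropeptide Y receptor type 1 (Homo sapiens), read by radioligand binding; a lower number here means a stronger inhibitor, a higher number a weaker inhibitor. Compound 1 `Nc1cc(S(=O)(=O)c2ccccc2)c([N+](=O)[O-])c2cccnc12` carries an amino group on the core and in this assay gives 297 nM. Compound 2 `Nc1ccc(Sc2cc(N)c3ncccc3c2[N+](=O)[O-])cc1` in this assay reaches only a limit, > 10000 nM, which is not a measured number. Compound 3 `Cc1cc(S(=O)(=O)c2ccccc2)c([N+](=O)[O-])c2cccnc12` in this assay likewise sits at a limit, > 10000 nM. So compound 3 stands at the top end of the numbers shown, and the one step that leads to it, an at least 33-fold higher number from compound 1 to compound 3 (1.52 log units; beyond the scatter), is large; that step is read against (the limit of > 10000 nM in this assay, at which 2 of the 3 values shown sit), so its true size is unknown.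

Compound 4 `CNc1cc(S(=O)(=O)c2ccccc2)c([N+](=O)[O-])c2cccnc12` differs from compound 3 in one place: methylamino in place of methyl on an aromatic carbon. This change restores an amine-type group of the kind compound 1 carries, though with a methyl on the nitrogen. Going by the values given here, the only measured step that bears on it is an at least 33-fold higher number from compound 1 to compound 3 (1.52 log units; beyond the scatter), which went from amino to methyl, and compound 4 undoes most of that change. A large downward move, back toward the value of compound 1, is therefore expected, and the step of an at least 16-fold lower number from compound 3 to compound 4 (1.22 log units; beyond the scatter) is expected to lie beyond the scatter. For compound 4 the estimate in this assay is 600 nM, with a range from 150 nM to 4000 nM.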

Compound 4, inhibition constant: > 10000 nM
Compound 4 ended at the assay's limit; the forecaster's own chance of this, stated with the estimate: 15%; at least 16-fold (1.22 log units) between middle value and limit.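

A single methyl in place of hydrogen on the nitrogen is enough to give an at least 33-fold higher number from compound 1 to compound 4 (1.52 log units; beyond the scatter) in this assay, so having a nitrogen on this aromatic carbon does not by itself keep the value of compound 1. The earlier step, an at least 33-fold higher number from compound 1 to compound 3 (1.52 log units; beyond the scatter), swapped the whole amino group for a methyl and left open whether any amine-type group would do here, but compound 4 shows that methylamino does not, and among the compounds shown, only compound 1 gives a measured number rather than a limit. Compound 3 and compound 4 both sit at a limit, so the step between them cannot be read and neither can be ranked against the other: the limit of > 10000 nM in this assay, at which 3 of the 4 values shown sit.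

On these data alone, how far past that limit compound 3 and compound 4 truly lie remains unknown, so the real size of both large steps is open, as is whether methylamino differs from methyl here at all. Also open, as far as these compounds go, is how a hydroxyl group or a fluorine on this carbon would compare with the amino group of compound 1, and whether a longer chain on the nitrogen, such as ethylamino, would behave like methylamino.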